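Carbonate to carbamate on a shared oxygenated core

The compounds below may be only part of what the source reports. "The series", "measured", "known", "first", "only" and "open" are said of these compounds alone.

Compound 1 `CC(=O)OC[C@H]1[C@H]2CC[C@@H](C)[C@]1(C)CC/C(C)=C/CC[C@@]1(C)O[C@@H]1[C@@H]2O` gives 80 nM in an assay (Oryctolagus cuniculus) for inhibition of platelet-activating factor receptor (Cavia porcellus); a lower number here means a stronger inhibitor, a higher number a weaker inhibitor. Compound 2 `COC(=O)OC[C@H]1[C@H]2CC[C@@H](C)[C@]1(C)CC/C(C)=C/CC[C@@]1(C)O[C@@H]1[C@@H]2O` gives 130 nM in this assay. For the measured compounds named here, the only step measured so far, a 1.6-fold higher number from compound 1 to compound 2 (0.21 log units; within the scatter), replaces a methyl on a carbonyl carbon with a methoxy and leaves the number where it was. On the two numbers shown, compound 2 holds the higher one, yet its gap to compound 1 is within the scatter, so neither compound can be called the weaker inhibitor.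

Compound 3 `C/C1=C\CC[C@@]2(C)O[C@@H]2[C@H](O)[C@@H]2CC[C@@H](C)[C@](C)(CC1)[C@H]2COC(=O)N(C)C` is not yet measured. It differs from compound 2 by dimethylamino in place of methoxy on a carbonyl carbon, the methoxycarbonyl becoming a dimethylcarbamoyl. Going by the values given here, no measured step touches a dimethylamino group; the one step that does bear on the same carbonyl carbon, from acetyl to methoxycarbonyl, was within the scatter, which suggests that changes at this carbonyl carbon are tolerated. Compound 3 is therefore expected to stay close to compound 2, with a step of a 1.2-fold higher number from compound 2 to compound 3 (0.06 log units; within the scatter) in this assay. The estimate for compound 3 is 150 nM, expected to fall between 55 nM and 400 nM.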

Compound 3, half-maximal inhibitory concentration: 180 nM
Compound 3: middle estimate off by 1.2-fold (0.08 log units), on the low side; the measured number falls inside the stated range.
By their numbers in this assay, from the lowest: compounds 1, 2 and 3 (each within the scatter of the next, the first and the last beyond it).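

In this assay dimethylamino in place of methoxy on a carbonyl carbon gives a 1.4-fold higher number from compound 2 to compound 3 (0.14 log units; within the scatter) and so, taken alone, this exchange does not move the number beyond what repeated measurements would show. Set against the methyl of compound 1, however, the same dimethylamino gives a 2.3-fold higher number from compound 1 to compound 3 (0.35 log units; beyond the scatter) and this is the first step at this carbonyl carbon to clear the scatter, though only modestly. Two steps that each stay within the scatter thus span a gap that does not, with compound 2 unresolved from either of the others, and nothing measured here accounts for the difference between the methyl and the dimethylamino.

On these data alone, what remains open is whether the gap belongs to the nitrogen itself or to the two methyl groups it carries: a plain amino or a methylamino on the same carbonyl carbon would separate those two readings. As far as these compounds go, it is also open how far this position reaches, for a longer chain such as propionyl, or a free hydroxymethyl in place of the whole ((dimethylcarbamoyl)oxy)methyl, would test it beyond these three close neighbours.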